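Two weak cytotoxic analogues and an untested furan ketone

The compounds below may be only part of what the source reports. "The series", "measured", "known", "first", "only" and "open" are said of these compounds alone.

The series shares one core, carried by compound 1 `COc1cc(-c2nnc3n2NC(c2cccs2)C(C(=O)c2ccccc2)S3)cc(OC)c1OC` and compound 2 `COc1cc(-c2nnc3n2NC(c2ccco2)C(C(=O)c2ccc(F)c(F)c2)S3)cc(OC)c1OC`. In a functional assay on A549 cells (Homo sapiens) for cytotoxicity, read by MTT assay, with a stated time of 48 h (on this read-out higher numbers stand for weaker inhibition and lower numbers for stronger inhibition), compound 1 gives 69400 nM. In this assay compound 2 gives 93700 nM, the highest of the two numbers available, though its gap to compound 1 lies within the usual scatter, so the two cannot be ordered against each other. Both stand at the weak end of what this read-out can show.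

Compound 3 `COc1cc(-c2nnc3n2NC(c2ccco2)C(C(=O)c2ccco2)S3)cc(OC)c1OC` has not yet been measured. It differs from compound 2 in one place: furan-2-yl in place of 3,4-difluorophenyl on a carbonyl carbon. Among the measured compounds shown here, no pair of measured compounds shares this change, so nothing in the data tells its direction. Since the two measured compounds sit so close together, compound 3 is expected to remain in the same weak region, with a step of a 1.2-fold lower number from compound 2 to compound 3 (0.07 log units; within the scatter) that is expected not to exceed the scatter. In this assay compound 3 is estimated to give 80000 nM, with a likely range from 30000 nM to 200000 nM.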

Compound 3, half-maximal inhibitory concentration: 68700 nM
Compound 3: middle estimate off by 1.2-fold (0.07 log units), on the high side, and the stated range covers the measured number.
By their numbers in this assay, from the lowest: compounds 3, 1 and 2 (each within the scatter of the next).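

Among the compounds shown here, this is the first step that can be read at this position. In this assay, furan-2-yl in place of 3,4-difluorophenyl on a carbonyl carbon gives a 1.4-fold lower number from compound 2 to compound 3 (0.13 log units; within the scatter). The two groups differ in ring size, in heavy atoms (8 leaving, 5 entering), in the fluorine atoms that leave and in the hydrogen-bond acceptor that enters, yet the read-out does not separate compound 2 from compound 3, so this exchange alone leaves the cytotoxicity indistinguishable from the weak level already seen. No measurement bears on why the change has so little effect.

Whether any group on this carbonyl carbon can move the read-out beyond the scatter remains open, since the compounds shown carry only aromatic rings there, and a basic amine such as a dimethylaminomethyl-substituted phenyl or a carboxylic acid on the phenyl ring would test a different kind of substituent. The compounds shown also leave open what the ring on the saturated carbon contributes on its own, as no pair isolates a change at that place.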